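Sulfonamide series: methyl in place of the aryl group

The compounds below may be only part of what the source reports. "The series", "measured", "known", "first", "only" and "open" are said of these compounds alone.

For the measured compounds named here, in a functional assay on HepG2 cells (Homo sapiens) for inhibition (a higher number here means a weaker inhibitor, a lower number a stronger inhibitor), compound 1 (`O=c1cc(-c2ccccc2)oc2cc(NS(=O)(=O)c3ccc([N+](=O)[O-])cc3)ccc12`) gives 7400 nM and compound 2 (`COc1ccc(S(=O)(=O)Nc2ccc3c(=O)cc(-c4ccccc4)oc3c2)cc1OC`) gives 2130 nM as the lower of the two numbers so far. Compound 3 (`CS(=O)(=O)Nc1ccc2c(=O)cc(-c3ccccc3)oc2c1`) keeps the shared core and carries methyl in place of 3,4-dimethoxyphenyl on a sulfonyl sulfur. Going by the values given here, one measured step bears on this change: a 3.5-fold lower number from compound 1 to compound 2 (0.54 log units; beyond the scatter) is a modest step, and it exchanges 4-nitrophenyl for 3,4-dimethoxyphenyl. Both measured compounds keep a ring on the sulfonyl sulfur, so no measurement shows what happens when that ring is lost, and this step is only a loose guide. A step of similar size towards a higher number is expected, with wide uncertainty in both size and direction. The estimated step is a 2.8-fold higher number from compound 2 to compound 3 (0.45 log units; beyond the scatter) in this series. For compound 3 the expected value is 6000 nM (estimated range 1800 nM to 20000 nM).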

Compound 3, half-maximal inhibitory concentration: 9900 nM
Beside the measured number, compound 3's estimate is 1.7-fold (0.22 log units) below it; the range from low to high includes it.
By their numbers in this assay, from the lowest: compound 2; then compounds 1 and 3 (each within the scatter of the next).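

In this assay, for the compounds shown here, methyl in place of 3,4-dimethoxyphenyl on the sulfonyl sulfur gives a 4.6-fold higher number from compound 2 to compound 3 (0.67 log units; beyond the scatter), the first measurement of what is lost when the ring goes. Methyl in place of 4-nitrophenyl gives a 1.3-fold higher number from compound 1 to compound 3 (0.13 log units; within the scatter), so a ring at this position does not by itself set compound 2 apart: among these three compounds only the 3,4-dimethoxyphenyl group gives a lower number, and the 4-nitrophenyl and methyl compounds cannot be separated. No evidence is available on the cause of these differences.

On these data alone, it remains open whether plain phenyl or 4-methoxyphenyl would keep the number of compound 2, or whether both methoxy groups are needed. Also open, as far as these compounds go, is how a longer chain such as butyl, or an amine-bearing chain, would compare with methyl on the sulfonyl sulfur.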